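The source may report more compounds than this note shows. Statements on the series, on what has been measured and on what is new or still open speak of the compounds shown alone.

Compound 1 `Brc1ccc(-c2cc(COc3ccccc3-c3nc4ccccc4s3)on2)cc1`: 20000 nM.
Compound 2 `FC(F)(F)C(F)(F)C(F)(F)C(F)(F)C(F)(F)C(F)(F)C(F)(F)C(F)(F)CCn1cc(COc2ccccc2-c2nc3ccccc3s2)nn1`: 19200 nM.

Both numbers come from a functional assay on MCF7 cells (Homo sapiens) for cytotoxicity, read by MTT assay, with a stated time of 24 h; a higher number here means a weaker inhibitor, a lower number a stronger inhibitor. Compound 1 stands level with compound 2, the gap between them lying within the scatter, so the pair reads as a single level. Among the measured compounds shown here, no step between measured compounds is available. Compound 3 `FC(F)(F)Oc1ccc(-c2cc(COc3ccccc3-c3nc4ccccc4s3)on2)cc1` is the one still unmeasured; it differs from compound 1 in one place: trifluoromethoxy in place of bromo on an aromatic carbon. Nothing measured shows how such a change moves this assay, so the step is expected to be small, a 1.1-fold lower number from compound 1 to compound 3 (0.05 log units; within the scatter), with no clear direction beyond the scatter. Compound 3 is therefore expected to give 18000 nM, within a range from 6000 nM to 50000 nM.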

Compound 3, half-maximal inhibitory concentration: 26600 nM
For compound 3 the middle estimate is 1.5-fold (0.17 log units) below the measured one; the range from low to high includes it.
By their numbers in this assay, from the lowest: compounds 2, 1 and 3 (each within the scatter of the next).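

In this assay, trifluoromethoxy in place of bromo on an aromatic carbon, para to a large group, gives a 1.3-fold higher number from compound 1 to compound 3 (0.12 log units; within the scatter). This first step read at this position shows that a group of five heavy atoms can replace a single bromine without moving the number beyond the scatter. No measured evidence on this change bears on the result. On these data alone, whether an amine or a carboxylic acid at this position would stay at the same level remains open. So does whether a change elsewhere on the shared core would move the number beyond the scatter.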